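The compounds below may be only part of what the source reports. "The series", "measured", "known", "first", "only" and "open" are said of these compounds alone.

Measured compounds in a functional assay on B16-BL6 cells (Mus musculus) for cytotoxicity, read by MTT assay, with a stated time of 48 h; on this read-out lower numbers stand for stronger inhibition and higher numbers for weaker inhibition:
Compound 1, `CNC(=O)c1ccc(Sc2ccc(NC(=S)Nc3cccc(C)c3)cc2)nc1`: compound 1 gives > 100000 nM, which is a limit of the assay and not a number.
Compound 2, `CNC(=O)c1ccc(Sc2ccc(NC(=S)Nc3ccc(F)c(F)c3)cc2)nc1`: compound 2 gives 52600 nM.
Compound 3, `CNC(=O)c1ccc(Sc2cccc(NC(=S)Nc3ccc(F)c(Cl)c3)c2)nc1`: compound 3 gives > 100000 nM, again a limit of the assay and not a number.

Compound 3 therefore stands at the limit, and the same holds for (the limit of > 100000 nM in this assay, at which 2 of the 3 values shown sit); only compound 2 gives a number at all. Among the measured compounds shown here, the one step measured is an at least 1.9-fold lower number from compound 1 to compound 2 (0.27 log units; that floor lies within the scatter), which moves from a limit to a number but is floored within the scatter. Compound 4, `CNC(=O)c1ccc(Sc2cccc(NC(=S)Nc3ccc(F)c(C(F)(F)F)c3)c2)nc1`, differs from compound 3 by trifluoromethyl in place of chloro on an aromatic carbon. For the measured compounds named here, no measured step covers this exchange: the only known step concerns other groups, so it bears on the present change only loosely. Going by the values given here, with compound 3 at the limit and no step of size beyond the scatter anywhere, the expectation is that a number no higher from compound 3 to compound 4 (the limit leaves the size open) is a step within the scatter, in no definite direction. Compound 4 is accordingly estimated at 100000 nM in this assay, with a range from 40000 nM to 300000 nM, and most likely reported again only as a limit.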

Compound 4, half-maximal inhibitory concentration: 42400 nM
Compound 4: the middle estimate sits 2.4-fold (0.37 log units) above what was measured; measured number inside the range.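

In this assay, trifluoromethyl in place of chloro on an aromatic carbon, ortho to a fluoro group, gives an at least 2.3-fold lower number from compound 3 to compound 4 (0.37 log units; beyond the scatter). Among the compounds shown here, this is the first step to clear the scatter, so the group on this carbon does matter to the read-out, and the group with more heavy atoms lies on the side of the lower number. The size of the step remains a floor only, because compound 3 sits at a limit of the assay: the limit of > 100000 nM in this assay, at which 2 of the 4 values shown sit.

The compounds shown leave open whether a methyl, a nitrile or a methoxy group on this carbon would fall with chloro or with trifluoromethyl. They also leave open whether the same exchange would act alike on the core of compound 2.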